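A few compounds are considered here, and "the series" means these few. Any claim that something is new, unique, unknown or untested is made for them only; others in the source may bear on it.

Three compounds share one core and differ only in the group carried on a single aromatic carbon. Compound 1 `CCCCN(C)c1nc(C(C)(C)C)ccc1CNC(=O)C(C)c1ccc(NS(C)(=O)=O)c(F)c1` bears butyl(methyl)amino there, and in an assay on cells for antagonist activity at transient receptor potential cation channel subfamily V member 1 (Homo sapiens), read by FLIPR and calcium flux, with a stated time of 6 min (a lower number here means a stronger inhibitor, a higher number a weaker inhibitor), compound 1 gives 1.2 nM. Compound 2 `CCOc1nc(C(C)(C)C)ccc1CNC(=O)C(C)c1ccc(NS(C)(=O)=O)c(F)c1` bears ethoxy, and in this assay compound 2 gives 14.8 nM. Compound 3 `CC(C(=O)NCc1ccc(C(C)(C)C)nc1OC1CCCCC1)c1ccc(NS(C)(=O)=O)c(F)c1` bears cyclohexyloxy, and in this assay compound 3 gives 2.5 nM. Compound 3 therefore holds the second highest number of the three: the steps read a 2.1-fold higher number from compound 1 to compound 3 (0.32 log units; beyond the scatter), a 12-fold higher number from compound 1 to compound 2 (1.09 log units; beyond the scatter) and a 5.9-fold lower number from compound 2 to compound 3 (0.77 log units; beyond the scatter).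

Compound 4 `CCOCCOc1nc(C(C)(C)C)ccc1CNC(=O)C(C)c1ccc(NS(C)(=O)=O)c(F)c1` is not yet measured. It differs from compound 3 in one place: 2-ethoxyethyl in place of cyclohexyl on an oxygen on an aromatic ring. Among the compounds with values here, the one measured step that bears directly on this change is the exchange of ethyl for cyclohexyl on the same oxygen, which gave a 5.9-fold lower number from compound 2 to compound 3 (0.77 log units; beyond the scatter). The new group is a chain rather than a ring, yet it is longer than ethyl, so compound 4 is expected to settle between compound 2 and compound 3, with a modest rise in the number, that is a 2.8-fold higher number from compound 3 to compound 4 (0.45 log units; beyond the scatter). In this assay compound 4 is thus estimated at 7 nM, with a likely range from 3 nM to 18 nM.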

Compound 4, inhibition constant: 23.9 nM
Compound 4: middle estimate off by 3.4-fold (0.53 log units), on the low side; the whole stated range lies below it.
By their numbers in this assay, from the lowest: compound 1; then compound 3; then compounds 2 and 4 (each within the scatter of the next).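

In this assay, adding ethoxy to the end of the ethyl on the oxygen gave a 1.6-fold higher number from compound 2 to compound 4 (0.21 log units; within the scatter), so compound 2 and compound 4 cannot be told apart, and extending this chain with ethoxy did not bring the lower number seen with cyclohexyl. The replacement of the ring gave a 9.6-fold higher number from compound 3 to compound 4 (0.98 log units; beyond the scatter) even though 2-ethoxyethyl has nearly as many heavy atoms as cyclohexyl, which shows that at this oxygen a similar heavy-atom count did not preserve the number given by the ring. The 2-ethoxyethoxy group also stands well apart from the amine of compound 1, with a 20-fold higher number from compound 1 to compound 4 (1.30 log units; beyond the scatter) in the same assay, so among the four compounds the two lowest numbers belong to butyl(methyl)amino and cyclohexyloxy.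

Going by these compounds, whether a plain butyl or hexyl chain on this oxygen, or a tetrahydropyranyl ring, would read with cyclohexyl or with 2-ethoxyethyl remains open, and so the separate roles of the ring and the ether oxygen cannot be assigned. Nothing shown here offers an explanation for these differences.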